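A few compounds are considered here, and "the series" means these few. Any claim that something is new, unique, unknown or untested is made for them only; others in the source may bear on it.

Measured so far in an assay on isolated protein for inhibition of polyamine deacetylase HDAC10 (Homo sapiens); on this read-out lower numbers stand for stronger inhibition and higher numbers for weaker inhibition:
compound 1, `O=C(NO)c1ccc(Cn2ccc3cc(C(=O)c4ccc(F)cc4)ccc32)cc1`, gives > 100000 nM, which is a limit of the assay and not a number.
compound 2, `COc1ccc(C(=O)c2ccc3c(ccn3Cc3ccc(C(=O)NO)cc3)c2)cc1`, gives 59800 nM.

Within the data shown here, compound 2 holds the only number in this assay; the other entry is a limit. Among the measured compounds shown here, the single measured step is an at least 1.6-fold lower number from compound 1 to compound 2 (0.22 log units; that floor lies within the scatter), and because it starts from the limit of > 100000 nM in this assay, at which 1 of the 2 values shown sits, its size is only a floor. Compound 3, `O=C(NO)c1ccc(Cn2ccc3cc(C(=O)c4ccc(Cl)cc4)ccc32)cc1`, differs from compound 2 by chloro in place of methoxy on an aromatic carbon. Chloro, like the fluoro of compound 1, brings no hydrogen-bond acceptor, so compound 3 is expected to move back toward compound 1 rather than past compound 2. The expected step is a 1.5-fold higher number from compound 2 to compound 3 (0.18 log units; within the scatter), a weakening that may stay within the scatter and may end at the limit. Compound 3 is estimated at 90000 nM, in the range 40000 nM to 200000 nM.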

Compound 3, half-maximal inhibitory concentration: > 100000 nM
Compound 3: no number, only a limit; the forecaster's own chance of this, stated with the estimate: 40%; middle value at least 1.1-fold (0.04 log units) away from the limit.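

In this assay compound 3 gives > 100000 nM, which is a limit of the assay and not a number. Chloro in place of methoxy on this aromatic carbon, para to a large group, gives an at least 1.6-fold higher number from compound 2 to compound 3 (0.22 log units; that floor lies within the scatter), so chloro joins fluoro at the limit and, of the three groups at this position, only methoxy gives a number, although that floor does not by itself place the change beyond the scatter. The step from compound 1 to compound 3 cannot be read, and the limit now holds most of the compounds shown: the limit of > 100000 nM in this assay, at which 2 of the 3 values shown sit.

Open, going by these compounds, is whether an amine, a hydroxy group or a longer alkoxy chain at this position would give a number in this assay. Also open, on these data alone, is how far compound 1 and compound 3 lie past the limit, and with it the true size of the steps to compound 2.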